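Removing a Methyl Group From the Ring of Compound 3

This account rests on a few compounds, and the source may have more. Where it says the series, first, only, none or still open, it means among the compounds named here.

Of the compounds shown here, three have so far been tested in a functional assay on the whole organism (stomach) with Rattus norvegicus as the target; on this read-out higher numbers stand for an effect only at larger amounts of compound and lower numbers for an effect already at smaller amounts. Compound 1 `N=C(S)CCCCCn1nc(-c2ccccc2)ccc1=O` gives 23.3 mg/kg in this assay. Compound 2 `Cc1ccc(=O)n(CCC(=N)S)n1` gives 43.2 mg/kg. Compound 3 `Cc1cc(-c2ccccc2)nn(CCC(=N)S)c1=O` gives 66.7 mg/kg, the highest of the three numbers; its gap to compound 2 lies within the scatter, while its gap to compound 1 lies beyond it, so compound 3 needs clearly more than compound 1.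

Compound 4 `N=C(S)CCn1nc(-c2ccccc2)ccc1=O` has not yet been measured. It differs from compound 3 in a single place: hydrogen in place of methyl on an aromatic carbon. The methyl is lost from an aromatic carbon of the six-membered ring that carries two nitrogen atoms, opposite the ring nitrogen and meta to the phenyl group.

Among the measured compounds shown here, no pair of measured compounds differs in exactly this way, so no direct guide exists. Because compound 1, which also lacks this methyl, gives 23.3 mg/kg, a somewhat lower number seems the more likely direction, but the estimated step of a 1.5-fold lower number from compound 3 to compound 4 (0.17 log units; within the scatter) is expected to stay within the scatter. Compound 4 is therefore estimated at 45 mg/kg, with a range from 20 mg/kg to 110 mg/kg.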

Compound 4, dose for half-maximal effect: 87.3 mg/kg
Beside the measured number, compound 4's estimate is 1.9-fold (0.29 log units) below it; the measured number falls inside the stated range.
By their numbers in this assay, from the lowest: compounds 1, 2, 3 and 4 (each within the scatter of the next, the first and the last beyond it).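

In this assay, hydrogen in place of methyl on this aromatic carbon gives a 1.3-fold higher number from compound 3 to compound 4 (0.12 log units; within the scatter), so with the phenyl group present, this methyl makes no difference that can be told from the scatter. The other two changes do go beyond the scatter: phenyl in place of methyl on an aromatic carbon gives a 2.0-fold higher number from compound 2 to compound 4 (0.31 log units; beyond the scatter), and a group of 3 heavy atoms in place of a group of 6 heavy atoms on the saturated chain gives a 3.7-fold higher number from compound 1 to compound 4 (0.57 log units; beyond the scatter). Nothing measured here explains any of these steps.

On these data alone, it remains open whether a different group on this aromatic carbon, such as a chlorine atom or an amine, would shift the number beyond the scatter. Also open, as far as these compounds go, is how the number behaves for a chain of intermediate length, and whether the methyl would matter on the longer chain of compound 1.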